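Aryl exchange on the shared core: compound 2 to compound 3

A few compounds are considered here, and "the series" means these few. Any claim that something is new, unique, unknown or untested is made for them only; others in the source may bear on it.

Values in a functional assay on HL-60 cells (Homo sapiens) for antiproliferative activity, with a stated time of 72 h; a higher number here means a weaker inhibitor, a lower number a stronger inhibitor:
- compound 1 `Nc1ncnn2c([C@@H]3O[C@H](CO)[C@@H](O)[C@H]3O)cc(C#Cc3cccs3)c12`: > 100000 nM
- compound 2 `Nc1ncnn2c([C@@H]3O[C@H](CO)[C@@H](O)[C@H]3O)cc(-c3ccc(F)cc3F)c12`: 99300 nM

Compound 1 gives only a limit, not a number: the limit of > 100000 nM in this assay, at which 1 of the 2 values shown sits. Among the compounds with values here, compound 2 holds the only actual number in this assay, at 99300 nM. Compound 3 `Nc1ncnn2c([C@@H]3O[C@H](CO)[C@@H](O)[C@H]3O)cc(-c3ccccc3Cl)c12` carries 2-chlorophenyl in place of 2,4-difluorophenyl on an aromatic carbon. Within the data shown here, the one measured step bearing on this is a number no higher from compound 1 to compound 2 (the limit leaves the size open), and it offers no size to carry over. No step beyond the scatter is therefore expected in this assay. The expected step is a 1.4-fold lower number from compound 2 to compound 3 (0.15 log units; within the scatter). The estimate for compound 3 is 70000 nM, with an expected range of 25000 nM to 100000 nM.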

Compound 3, half-maximal inhibitory concentration: > 100000 nM
Compound 3 gave a limit, no number; the forecaster's own chance of this, stated with the estimate: 40%; middle value at least 1.4-fold (0.15 log units) away from the limit.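

In this assay the exchange gives a number no lower from compound 2 to compound 3 (the limit leaves the size open) and so 2-chlorophenyl brings no stronger number than 2,4-difluorophenyl at this aromatic carbon. Compound 3 gives a limit and not a number, as compound 1 does: the limit of > 100000 nM in this assay, at which 2 of the 3 values shown sit. The step between compound 1 and compound 3 cannot be read.

No change at this carbon has a readable size yet. As far as these compounds go, whether a methyl group, or a phenyl ring carrying an amine or a carboxylic acid, would give a clearly stronger number stays open.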